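Swapping chloro for amino on two related cores

This account rests on a few compounds, and the source may have more. Where it says the series, first, only, none or still open, it means among the compounds named here.

Of the compounds shown here, three have been measured in a functional assay on LS174T cells (Homo sapiens) for inhibition, with a stated time of 4 days, tested at 1 uM; a higher number here means a stronger effect of the compound at the concentration tested, a lower number a weaker effect. Compound 1, `Fc1cccc(F)c1C#Cc1ccc2nccc(Cl)c2c1`, gives 43.8% in this assay. Compound 2, `Nc1ccnc2ccc(C#Cc3c(F)cccc3F)cc12`, gives 66.2%. The two share a core and differ by one change, (amino in place of chloro on an aromatic carbon), and that change made the step of a number 22.4 percentage points higher from compound 1 to compound 2 (beyond the scatter).

Compound 3, `Fc1cccc(F)c1C#Cc1cnc(Cl)c2ccccc12`, is built from the same atoms as compound 1, joined differently; how the two cores differ is not broken down here. In this assay, for the measured compounds named here, compound 3 gives 48.1%, a number that lies within the scatter of the one for compound 1, while the number for compound 2 is higher than it beyond the scatter.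

Compound 4, `Nc1ncc(C#Cc2c(F)cccc2F)c2ccccc12`, has not yet been measured. Going by the values given here, it arises from compound 3 by the same kind of change as the one from compound 1 to compound 2: amino in place of chloro on an aromatic carbon. The surroundings are not identical, though: in compound 1 the chloro sits opposite the ring nitrogen, whereas in compound 3 it sits next to the ring nitrogen and para to a large group. With a single earlier example, the expectation rests on that one step alone. The expected step is a number 16.9 percentage points higher from compound 3 to compound 4 (beyond the scatter), kept a little smaller than the earlier one to allow for the different surroundings. Compound 4 is estimated at 65% in this assay, within a range from 45% to 85%.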

Compound 4, a percentage reported as inhibition, at one concentration (the size of the read-out at that concentration, not a potency): 86.2%
The estimate for compound 4 lay 21.2 percentage points below the measured number; measured number above the stated range.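

In this assay, putting amino in place of chloro on an aromatic carbon again raised the number, this time by a larger margin: a number 38.1 percentage points higher from compound 3 to compound 4 (beyond the scatter). Set side by side, the two cases agree in direction but not in size: the same change on two cores in this assay, a number 22.4 percentage points higher (beyond the scatter) from compound 1 to compound 2 and a number 38.1 percentage points higher (beyond the scatter) from compound 3 to compound 4, 15.7 percentage points apart, beyond the scatter of two such steps. For the compounds shown here, this shows that, across these two cores, the change goes the same way, but the size of the step on one core is a poor guide to its size on the other; with only two examples, it does not show that the direction would hold on further cores, nor what sets the size of the step.

The compounds shown carry only chloro or amino at this place, which leaves open how a methylamino group, a hydroxyl group or a plain hydrogen would fare on either core. On these data alone, each number is also a read-out at a single concentration and not a potency, so how the two amino compounds, compound 2 and compound 4, would compare at other concentrations stays open too.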